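From phenyl to 4-hydroxyphenyl on compound 2

The compounds below may be only part of what the source reports. "The series", "measured", "known", "first", "only" and "open" are said of these compounds alone.

Values in a functional assay on T47D cells (Homo sapiens) for cytotoxicity, read by colorimetric assay and MTT assay; on this read-out lower numbers stand for stronger inhibition and higher numbers for weaker inhibition:
- Compound 1 `COc1ccc2cc(-c3ccccc3)c(O)nc2c1`: 10000 nM
- Compound 2 `COc1cc(OC)c2cc(-c3ccccc3)c(O)nc2c1`: 10000 nM
- Compound 3 `CCN(CC)C(=O)CCn1c(=O)c(-c2ccc(OC)cc2)cc2c(OC)cc(OC)cc21`: 10000 nM

Compound 2, at 10000 nM, stands level with compound 1 and compound 3 in this assay. Compound 4 `COc1cc(OC)c2cc(-c3ccc(O)cc3)c(O)nc2c1` departs from compound 2 by one change, (hydroxy in place of hydrogen on an aromatic carbon), hydroxy in place of hydrogen on an aromatic carbon. For the measured compounds named here, the only measured step of this kind is no change at the digits printed from compound 1 to compound 2 (within the scatter), with methoxy in place of hydrogen on an aromatic carbon. Going by the values given here, it is a different group, and no measured compound carries the 4-hydroxyphenyl group, so it guides only loosely. The expected step is a 1.3-fold lower number from compound 2 to compound 4 (0.10 log units; within the scatter), none beyond the scatter in this assay. For compound 4 the estimated value is 8000 nM, within an expected range from 2500 nM to 12000 nM.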

Compound 4, half-maximal inhibitory concentration: 10000 nM
For compound 4 the middle estimate is 1.3-fold (0.10 log units) below the measured one; measured number inside the range.
By their numbers in this assay, from the lowest: compounds 1, 2, 3 and 4 (each within the scatter of the next).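

In this assay, hydroxy in place of hydrogen on an aromatic carbon, para to a large group, gives no change at the digits printed from compound 2 to compound 4 (within the scatter) and so extends the flat picture from the shared core to the phenyl group itself. The entering hydroxy adds a hydrogen-bond donor and acceptor at this place, yet the printed number stays the same. Nothing available accounts for this result. Going by these compounds, whether an amine, a carboxylic acid or a longer chain at this same place would separate from compound 2 remains open.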